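The source may report more compounds than this note shows. Statements on the series, on what has been measured and on what is new or still open speak of the compounds shown alone.

Compound 1 `Cc1ccc(C(=O)Nc2cccc(-c3oc4cc(-c5ccc(F)cc5)ccc4c(=O)c3O)c2)cc1` gives 6910 nM
Compound 2 `Cc1ccccc1C(=O)Nc1cccc(-c2oc3cc(-c4ccc(F)cc4)ccc3c(=O)c2O)c1` gives 17600 nM
Compound 3 `O=C(Nc1cccc(-c2oc3cc(-c4ccc(F)cc4)ccc3c(=O)c2O)c1)c1ccc(Cl)nc1` gives 3580 nM

These three numbers come from a functional assay on A549 cells (Homo sapiens) for antiproliferative activity, read by CCK-8 assay, with a stated time of 72 h; on this read-out higher numbers stand for weaker inhibition and lower numbers for stronger inhibition. Among them compound 1 stands second highest: the nearest number is reached by a 1.9-fold lower number from compound 1 to compound 3 (0.29 log units; within the scatter) and the furthest by a 2.5-fold higher number from compound 1 to compound 2 (0.41 log units; beyond the scatter). Compound 2 and compound 3 are separated by a 4.9-fold lower number from compound 2 to compound 3 (0.69 log units; beyond the scatter).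

Compound 4 `O=C(Nc1cccc(-c2oc3cc(-c4ccc(F)cc4)ccc3c(=O)c2O)c1)c1ccc(-c2ccccc2)cc1` has not yet been measured. It differs from compound 1 in one place: phenyl in place of methyl on an aromatic carbon. Only the two steps starting from compound 1 bear on this change, and neither touches the same position in the same way: a 2.5-fold higher number from compound 1 to compound 2 (0.41 log units; beyond the scatter) exchanges 4-methylphenyl for 2-methylphenyl, and a 1.9-fold lower number from compound 1 to compound 3 (0.29 log units; within the scatter) exchanges the whole ring for 6-chloropyridin-3-yl. The measured set therefore gives no clear direction for a phenyl in place of methyl at this site.

Compound 4 is expected to lie close to compound 1, with a 1.3-fold lower number from compound 1 to compound 4 (0.10 log units; within the scatter) not clearly beyond the scatter. The estimate for compound 4 is 5500 nM, expected to fall between 1500 nM and 18000 nM.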

Compound 4, half-maximal inhibitory concentration: > 100000 nM
Compound 4 gave a limit, no number; the forecaster's own chance of this, stated with the estimate: 5%; middle value at least 18-fold (1.25 log units) away from the limit.
By their numbers in this assay, from the lowest: compounds 3 and 1 (each within the scatter of the next); then compound 2. At a limit, above all of these: compound 4.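

Compound 4 gives only a limit in this assay, not a number: the limit of > 100000 nM in this assay, at which 1 of the 4 values shown sits. Going from 4-methylphenyl to 4-phenylphenyl, with phenyl in place of methyl on an aromatic carbon para to a large group, produces the first large step in the series, an at least 14-fold higher number from compound 1 to compound 4 (1.16 log units; beyond the scatter). Compound 4 also stands apart from the other two, with an at least 27-fold higher number from compound 3 to compound 4 (1.44 log units; beyond the scatter) and an at least 5.6-fold higher number from compound 2 to compound 4 (0.75 log units; beyond the scatter), so the earlier modest differences gave no sign that a change at this site could push the read-out to the limit of the assay.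

The compounds shown leave open where between methyl and phenyl this loss sets in, for example with an ethyl group, a methoxy group or a longer chain on the same carbon. They also leave open whether an amine or a carboxylic acid on the added phenyl would bring a measurable number back.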